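The compounds below may be only part of what the source reports. "The series", "measured", "known", "first", "only" and "open" are said of these compounds alone.

In a functional assay on A549 cells (Homo sapiens) for inhibition, read by MTT assay, with a stated time of 48 h (on this read-out lower numbers stand for stronger inhibition of growth and higher numbers for weaker inhibition of growth), compound 1 `Cn1cc(C2CC(c3ccccc3)=NN2C(=O)c2cccnc2)c2ccccc21` gives > 10000 nM. That value is a limit of the assay, not a number. Among the measured compounds shown here, compound 2 `Cn1cc(C2CC(c3ccccc3)=NN2C(=O)c2cccnc2)c2cc(Br)ccc21` gives 1600 nM, the only true number so far in this assay.

Compound 3 `Cn1cc(C2CC(c3ccc(Cl)cc3)=NN2C(=O)c2cccnc2)c2cc(Br)ccc21` differs from compound 2 by chloro in place of hydrogen on an aromatic carbon, turning phenyl into 4-chlorophenyl, para to a large group.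

For the measured compounds named here, only one measured step bears on this change. With bromo in place of hydrogen on an aromatic carbon, the data show an at least 6.2-fold lower number from compound 1 to compound 2 (0.79 log units; beyond the scatter). That halogen sits on a different ring, so this single step is weak guidance. It points to a lower number, but a smaller drop is expected here. The expected step is a 2.0-fold lower number from compound 2 to compound 3 (0.30 log units; within the scatter), close to the scatter. For compound 3 the estimated value is 800 nM, within an expected range of 250 nM to 2500 nM.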

Compound 3, concentration for 50% growth inhibition: 7650 nM
Estimate against measurement, compound 3: 9.6-fold (0.98 log units) below; the measured number lies above the stated range.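

In this assay, turning phenyl into 4-chlorophenyl gives a 4.8-fold higher number from compound 2 to compound 3 (0.68 log units; beyond the scatter), a change beyond the scatter, so this place on the phenyl ring does respond to substitution. The two halogen steps run in opposite directions: on the other ring, bromo gave an at least 6.2-fold lower number from compound 1 to compound 2 (0.79 log units; beyond the scatter), and that gain does not carry over to chloro on the phenyl ring. Compound 1 stands at a limit of the assay, so the size of the bromo step stays open at its upper end: the limit of > 10000 nM in this assay, at which 1 of the 3 values shown sits.

The compounds shown cannot tell whether the loss belongs to chloro itself or to any group at this place. A fluoro, a methoxy or an amine on the same carbon would help to separate these two readings.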